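Aryl Amide Replacement of Cyclopropyl in a Naphthylamide Series

The source may report more compounds than this note shows. Statements on the series, on what has been measured and on what is new or still open speak of the compounds shown alone.

Measured compounds in an assay on LtK cells with ATP-sensitive inward rectifier potassium channel 11 (Homo sapiens) as the target; a lower number here means that less compound is needed, a higher number that more compound is needed for the effect:
- compound 1 `O=C(Nc1c(C(O)(C(F)(F)F)C(F)(F)F)ccc2ccccc12)C1CC1`: 751 nM
- compound 2 `O=C(Nc1ccc(Cl)cc1)Nc1c(C(O)(C(F)(F)F)C(F)(F)F)ccc2ccccc12`: 276 nM
- compound 3 `Cc1ccccc1C(=O)Nc1c(C(O)(C(F)(F)F)C(F)(F)F)ccc2ccccc12`: 5550 nM

Compound 1 sits second highest of the three numbers. Compound 2 gives the lower number, a 2.7-fold lower number from compound 1 to compound 2 (0.43 log units; beyond the scatter), while compound 3 gives the higher one, a 7.4-fold higher number from compound 1 to compound 3 (0.87 log units; beyond the scatter); between compound 2 and compound 3 the gap is a 20-fold higher number from compound 2 to compound 3 (1.30 log units; beyond the scatter).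

The unmeasured compound 4 `Cc1cccc(C(=O)Nc2c(C(O)(C(F)(F)F)C(F)(F)F)ccc3ccccc23)c1` differs from compound 1 at one place: 3-methylphenyl in place of cyclopropyl on a carbonyl carbon. Among the compounds with values here, the step that bears most directly on this is the one to compound 3, where 2-methylphenyl replaced cyclopropyl on the same carbonyl carbon and gave a 7.4-fold higher number from compound 1 to compound 3 (0.87 log units; beyond the scatter). As far as these compounds go, compound 4 carries the methyl on a different carbon of the ring, so the exact size of its step is unknown, but swapping cyclopropyl for a methylated phenyl on this carbonyl has so far pushed the number up. A higher number than compound 1 is therefore expected in this assay, probably by less than in compound 3, estimated at a 3.3-fold higher number from compound 1 to compound 4 (0.52 log units; beyond the scatter). Compound 4 is expected to give 2500 nM, within 900 nM to 7000 nM.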

Compound 4, half-maximal effective concentration: 23 nM
For compound 4 the middle estimate is 110-fold (2.04 log units) above the measured one; measured number below the stated range.
By their numbers in this assay, from the lowest: compound 4; then compound 2; then compound 1; then compound 3.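

In this assay, 3-methylphenyl reverses the direction seen with 2-methylphenyl on this carbonyl carbon, giving a 33-fold lower number from compound 1 to compound 4 (1.51 log units; beyond the scatter), so replacing cyclopropyl with a methylated phenyl does not in itself raise the number. The place of the methyl on the ring matters greatly here: the change from 2-methylphenyl to 3-methylphenyl gives a 240-fold lower number from compound 3 to compound 4 (2.38 log units; beyond the scatter), the largest step in the set. The (4-chlorophenyl)amino group of compound 2 also no longer gives the lowest number, with a 12-fold lower number from compound 2 to compound 4 (1.08 log units; beyond the scatter).

No measurement at hand accounts for the gap between the two methylphenyl groups. As far as these compounds go, it remains open whether unsubstituted phenyl, 4-methylphenyl, 3-chlorophenyl or 3-methoxyphenyl would match compound 4, and whether a longer chain or an amine on the 3-methylphenyl ring would keep its low number.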